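A few compounds are considered here, and "the series" means these few. Any claim that something is new, unique, unknown or untested is made for them only; others in the source may bear on it.

Of the compounds shown here, three that share one core have been measured. Compound 1 `C#CCNC1CCc2c(NCc3cccc(F)c3)cccc21` gives 1860 nM in an assay on cells for inhibition of Amine oxidase [flavin-containing] B (Homo sapiens), read by fluorescence and Amplex Red, with stated times of 30 min and 15 min; on this read-out higher numbers stand for weaker inhibition and lower numbers for stronger inhibition. Compound 2 `C#CCNC1CCc2c(SCc3ccc(F)cc3)cccc21` gives 240 nM in this assay, and compound 3 `C#CCNC1CCc2c(OCCc3cc(NC(C)=O)ccc3Cl)cccc21` gives 590 nM in this assay. Among these three numbers compound 3 stands second highest: its nearest neighbour is compound 2, whose number is lower by a margin beyond the usual scatter, while compound 1 lies furthest away, with a higher number that is also beyond the scatter. No two of the measured compounds differ in only one place, so no single step can be read off from them.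

Compound 4 `C#CCNC1CCc2c(OCCc3cc(NC(=O)COC(C)=O)ccc3Cl)cccc21` has not yet been measured. It differs from compound 3 by acetoxy in place of hydrogen on a saturated chain carbon bound to a carbonyl carbon. Going by the values given here, no measured pair shows such a change, so any expectation rests on judgement alone. The step is expected to be modest and to move the number upward, towards weaker inhibition, by a 1.4-fold higher number from compound 3 to compound 4 (0.13 log units; within the scatter) in this assay, although a result within the scatter would not be surprising. On that basis compound 4 is expected to give about 800 nM in this assay, with a likely range from 300 nM to 2000 nM.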

Compound 4, half-maximal inhibitory concentration: 480 nM
Estimate against measurement, compound 4: 1.7-fold (0.22 log units) above; the measured number falls inside the stated range.
By their numbers in this assay, from the lowest: compounds 2, 4 and 3 (each within the scatter of the next, the first and the last beyond it); then compound 1.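

Going by these compounds alone, this is the first change that can be read in one place. In this assay the acetoxy group in place of hydrogen on a saturated chain carbon bound to a carbonyl carbon gives a 1.2-fold lower number from compound 3 to compound 4 (0.09 log units; within the scatter) and so leaves the two compounds indistinguishable, even though the acetamido group has grown into ((acetoxymethyl)carbonyl)amino, with 4 more heavy atoms and 2 more hydrogen-bond acceptors. Within this one pair, then, that added bulk of atoms at this carbon comes with no change that can be told from ordinary repeat variation, and no supporting measurement is available to explain the result.

A single pair cannot show whether this holds for other groups on the same carbon, such as an amine, a carboxylic acid, a hydroxyl or a longer chain, or whether it depends on the ester in the acetoxy group. On these data alone, it also remains open whether the same change would behave alike on the different side chains of compound 1 and compound 2, whose links to the shared core are not the same.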